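Aryl ether in place of cyclohexyl ether on the benzamide

The compounds below may be only part of what the source reports. "The series", "measured", "known", "first", "only" and "open" are said of these compounds alone.

The series shares a pyrazole-bearing benzamide core with an ether arm on the benzamide ring. Compound 1 `Cc1nn(Cc2ccccc2)c(C)c1NC(=O)c1ccc(COc2ccccc2)cc1` carries a phenoxy arm and in a functional assay on MIA PaCa-2 cells (Homo sapiens) for antiproliferative activity, read by MTT assay, with a stated time of 72 h (on this read-out lower numbers stand for an effect already at smaller amounts and higher numbers for an effect only at larger amounts of compound), compound 1 gives 10000 nM. Compound 2 `CNC(=O)c1cccc(Cn2nc(C)c(NC(=O)c3ccc(COC4CCCCC4)cc3)c2C)c1` carries a cyclohexyloxy arm together with a methylcarbamoyl group on the benzyl side, and in this assay compound 2 gives 14000 nM. Of the two numbers compound 2 has the higher one, but the gap to compound 1 lies within the scatter, so the two compounds cannot be told apart on these data.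

Compound 3 `CNC(=O)c1cccc(Cn2nc(C)c(NC(=O)c3ccc(COc4ccc(Cl)cc4)cc3)c2C)c1` keeps everything of compound 2 except one change: 4-chlorophenyl in place of cyclohexyl on an oxygen on a saturated carbon. Among the measured compounds shown here, no measured pair shows this exact exchange. For the measured compounds named here, the only related point is compound 1, whose phenoxy arm gave 10000 nM, which suggests an aryl ether is tolerated at about the same level as the cyclohexyl ether. The step is therefore expected to be small, a 1.8-fold lower number from compound 2 to compound 3 (0.24 log units; within the scatter), pointing if anything to a slightly lower number. Compound 3 is estimated at 8000 nM in this assay, with a range from 3000 nM to 25000 nM.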

Compound 3, half-maximal effective concentration: 4200 nM
Beside the measured number, compound 3's estimate is 1.9-fold (0.28 log units) above it; the measured number falls inside the stated range.
By their numbers in this assay, from the lowest: compound 3; then compounds 1 and 2 (each within the scatter of the next).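

At this position, on an oxygen on a saturated carbon, 4-chlorophenyl in place of cyclohexyl gives in this assay a 3.3-fold lower number from compound 2 to compound 3 (0.52 log units; beyond the scatter), a modest step but one beyond the scatter. Compound 1 and compound 2 differ in more than one place and could not be told apart, so neither said anything about this position alone; this pair, which differs in one place, shows that the group on this oxygen can move the number in this assay. The compounds shown offer no evidence that would account for the step.

The exchange replaces a non-aromatic ring of carbon with an aromatic one and brings in a chlorine at the same time, so the shown compounds cannot separate the contribution of the ring from that of the chlorine. On these data alone, it remains open how the arm of compound 3 would respond if 4-chlorophenyl gave way to 4-methoxyphenyl or 4-fluorophenyl, or if a piperidine or a longer carbon chain stood on this oxygen.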